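Sulfur-linked acid chain variants in a urate transporter series

The source may hold more compounds than are shown below. What is called first, only, known or untested is meant among the compounds shown, and "the series" means these compounds.

Compound 3 `N#Cc1ccc(Oc2cnccc2SCCCC(=O)O)c2ccccc12` gives 1230 nM in an assay on HEK293 cells for inhibition of solute carrier family 22 member 12 (Homo sapiens), read by scintillation counting, with stated times of 30 min and 15 min; on this read-out lower numbers stand for stronger inhibition and higher numbers for weaker inhibition. Compound 1 `CC(C)(Sc1ccncc1Oc1ccc(C#N)c2ccccc12)C(=O)O` differs from it by 1-carboxy-1-methylethyl in place of 3-carboxypropyl on a sulfur and gives 5210 nM in this assay, a step of a 4.2-fold higher number from compound 3 to compound 1 (0.63 log units; beyond the scatter). Compound 2 `CN(c1cnccc1SCCCC(=O)O)c1ccc(C#N)c2ccccc12` carries a different core; the difference between the cores of compound 2 and compound 3 is not broken down here. In this assay compound 2 gives 2580 nM. Compound 4 `CN(c1cnccc1SC(C)(C)C(=O)O)c1ccc(C#N)c2ccccc12` has not been measured and differs from compound 2 by 1-carboxy-1-methylethyl in place of 3-carboxypropyl on a sulfur, the same change at the same place as from compound 3 to compound 1. Going by the values given here, only one measured pair shows this change, so the expectation rests on that single step. A comparable weakening is expected, a 3.9-fold higher number from compound 2 to compound 4 (0.59 log units; beyond the scatter), because a 4.2-fold higher number from compound 3 to compound 1 (0.63 log units; beyond the scatter) was seen for the same change. Compound 4 is therefore expected to give 10000 nM, within a range from 4000 nM to 25000 nM.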

Compound 4, half-maximal inhibitory concentration: 5360 nM
For compound 4 the middle estimate is 1.9-fold (0.27 log units) above the measured one; the range from low to high includes it.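

Setting 1-carboxy-1-methylethyl in place of 3-carboxypropyl on the sulfur gives a 2.1-fold higher number from compound 2 to compound 4 (0.32 log units; beyond the scatter) in this assay. The change raises the number on both cores, and the two steps do not differ in size beyond the scatter: the same change on two cores in this assay, a 4.2-fold higher number (0.63 log units; beyond the scatter) from compound 3 to compound 1 and a 2.1-fold higher number (0.32 log units; beyond the scatter) from compound 2 to compound 4, 2.0-fold (0.31 log units) apart, within the scatter of two such steps. This supports carrying the change between these two cores only; two pairs set no rule for other cores and do not show why the number rises.

Still open, going by these compounds, is how other groups on the sulfur would read on these cores, such as a carboxymethyl chain, a longer chain, or a tetrazole in place of the carboxylic acid. Also open, on these data alone, is whether the step holds with a methylene or a sulfur in place of the linking oxygen of compound 3.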